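Replacing the group on sulfur: compound 3 to compound 4

This account rests on a few compounds, and the source may have more. Where it says the series, first, only, none or still open, it means among the compounds named here.

In a functional assay on HT-29 cells (Homo sapiens) for cytotoxicity, read by MTT assay, with a stated time of 24 h (a higher number here means a weaker inhibitor, a lower number a stronger inhibitor), compound 1 `Cn1c(-c2ccc(NC(=O)CCl)cc2)nc(-c2ccccc2)c1-c1ccccc1` gives 28.7 ug/mL, compound 2 `Cn1c(-c2ccc(NC(=O)CSc3nc4ccccc4o3)cc2)nc(-c2ccccc2)c1-c1ccccc1` gives 11 ug/mL and compound 3 `Cc1ccc2oc(SCC(=O)Nc3ccc(-c4nc(-c5ccccc5)c(-c5ccccc5)n4C)cc3)nc2c1` gives 22.4 ug/mL. The measured steps are a 2.6-fold lower number from compound 1 to compound 2 (0.42 log units; beyond the scatter), a 1.3-fold lower number from compound 1 to compound 3 (0.11 log units; within the scatter) and a 2.0-fold higher number from compound 2 to compound 3 (0.31 log units; beyond the scatter). Compound 3 therefore matches compound 1 within the scatter and carries a higher number than compound 2. The next change, to compound 4 `Cc1nnc(SCC(=O)Nc2ccc(-c3nc(-c4ccccc4)c(-c4ccccc4)n3C)cc2)s1`, is 5-methyl-1,3,4-thiadiazol-2-yl in place of 5-methyl-1,3-benzoxazol-2-yl on a sulfur. For the measured compounds named here, no measured compound carries the entering group, so the evidence is indirect, but the steps above are modest or within the scatter. No step beyond the scatter is expected, and the estimated step is a 1.1-fold lower number from compound 3 to compound 4 (0.05 log units; within the scatter). Compound 4 is expected at 20 ug/mL, with an estimated range of 9 ug/mL to 45 ug/mL.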

Compound 4, half-maximal inhibitory concentration: 2.7 ug/mL
Compound 4: middle estimate off by 7.4-fold (0.87 log units), on the high side; the measured number lies below the stated range.
By their numbers in this assay, from the lowest: compound 4; then compound 2; then compounds 3 and 1 (each within the scatter of the next).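

For the compounds shown here, on the sulfur, the choice of ring system counts for more in this assay than the earlier compounds showed: 5-methyl-1,3,4-thiadiazol-2-yl in place of 5-methyl-1,3-benzoxazol-2-yl gives an 8.3-fold lower number from compound 3 to compound 4 (0.92 log units; beyond the scatter) and so far exceeds the methyl step among the benzoxazoles. The same group also gives a 4.1-fold lower number from compound 2 to compound 4 (0.61 log units; beyond the scatter) against 1,3-benzoxazol-2-yl and an 11-fold lower number from compound 1 to compound 4 (1.03 log units; beyond the scatter) against chloro, leaving compound 4 with the lowest number of the four. No measurement offered here bears on the reason for these steps.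

Open, as far as these compounds go, is how the number responds to hydrogen or an amine in place of the methyl on the 1,3,4-thiadiazol-2-yl ring. Also open, from the compounds shown here alone, is whether a longer chain in place of the saturated chain carbon on the sulfur keeps the step.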